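The compounds below may be only part of what the source reports. "The series", "measured", "known", "first", "only" and "open" are said of these compounds alone.

In a physicochemical assay for solubility (a lower number here means a less soluble compound, a higher number a more soluble compound), compound 1 (`O=C(O)c1ccc(C(=O)/C(=C\c2ccc(Cl)c([N+](=O)[O-])c2)SCc2ccc(Cl)cc2)cc1`) reads < 1000 ug/mL and this is a limit, not a number. Compound 2 (`O=C(O)c1ccc(C(=O)/C(=C\c2ccc(O)c([N+](=O)[O-])c2)SCc2ccc(Br)cc2)cc1`) reads < 1000 ug/mL and this too is a limit. Compound 3 (`O=C(O)c1ccc(C(=O)/C(=C\c2ccc(Br)c([N+](=O)[O-])c2)SCc2ccc(Cl)cc2)cc1`) reads < 1000 ug/mL and that is again only a limit, so it has no number of its own to start from. Within the data shown here, the series so far comes down to the limit of < 1000 ug/mL in this assay, at which 3 of the 3 values shown sit, with no number among them.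

Compound 4 (`O=C(O)c1ccc(C(=O)/C(=C\c2ccc(Br)c([N+](=O)[O-])c2)SCc2ccc(F)cc2)cc1`) differs from compound 3 by one change: fluoro in place of chloro on an aromatic carbon with fluoro in place of chloro on an aromatic carbon, para to a large group, which turns the (4-chlorobenzyl)sulfanyl group into (4-fluorobenzyl)sulfanyl. Among the measured compounds shown here, the one measured step that bears on this is also an exchange of one halogen for another. With a step that the two limits leave unreadable from compound 1 to compound 3 for bromo in place of chloro on an aromatic carbon offering no size, no step beyond the scatter is expected in this assay in either direction. The estimated step is a step that the limit leaves unreadable from compound 3 to compound 4 and it carries little weight. For compound 4 the estimate is 500 ug/mL with an expected range from 150 ug/mL to 1000 ug/mL and a report of only a limit remains the likeliest outcome.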

Compound 4, solubility: < 1000 ug/mL
Compound 4: a limit, no number (the forecaster's own chance of this, stated with the estimate: 90%); the middle value is on the limit's open side.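

Compound 3 and compound 4 both read as limits in this assay, not as numbers, so no step can be read between them. The compounds shown leave open where any of them truly falls in this assay and whether exchanging one halogen for another moves that value at all, as the series rests on a single reading: the limit of < 1000 ug/mL in this assay, at which 4 of the 4 values shown sit.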